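The source may report more compounds than this note shows. Statements on the series, on what has been measured and on what is new or still open speak of the compounds shown alone.

Compound 2 `COc1ncc(-c2ccccc2)cc1[C@@H](c1ccccc1)[C@@](O)(CCN(C)C)c1ccccc1` stands in a toxicity assay on Vero cells (Chlorocebus sabaeus) for cytotoxicity (on this read-out lower numbers stand for higher toxicity in this test and higher numbers for lower toxicity in this test), at a reading that is only a limit. In this assay compound 2 gives > 50 ug/mL, a limit of the assay. Compound 1 `COc1ncc(-c2ccccc2)cc1[C@@H](c1ccccc1)[C@@](O)(CCN(C)C)c1cc(F)cc(F)c1` gives > 50 ug/mL in this assay, likewise a limit. The step that the two limits leave unreadable from compound 1 to compound 2 cannot be sized, since the limit of > 50 ug/mL in this assay, at which 2 of the 2 values shown sit, covers both readings. Compound 3 `COc1ncc(-c2ccccc2)cc1[C@@H](c1ccccc1)[C@@](O)(CCN(C)C)c1cccc2ccccc12` differs from compound 2 by naphthalen-1-yl in place of phenyl on a saturated chain carbon bound to an oxygen on a saturated carbon and two saturated chain carbons. No readable measured step bears on this change, so the expected step of an at least 1.2-fold lower number from compound 2 to compound 3 (0.09 log units; that floor lies within the scatter) rests on the two limits alone. For compound 3 a value of 40 ug/mL is estimated in this assay, with a range from 12 ug/mL to 100 ug/mL.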

Compound 3, half-maximal cytotoxic concentration: > 50 ug/mL
Compound 3 ended at the assay's limit; the forecaster's own chance of this, stated with the estimate: 45%; middle value at least 1.2-fold (0.09 log units) away from the limit.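

No new step can be read among compound 1, compound 2 and compound 3, which all share one limit: the limit of > 50 ug/mL in this assay, at which 3 of the 3 values shown sit. The compounds shown leave open whether phenyl, 3,5-difluorophenyl and naphthalen-1-yl differ at all in this assay.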